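The compounds below may be only part of what the source reports. "The series", "measured", "known", "first", "only" and "open" are said of these compounds alone.

Compound 1 `COc1cc(/C=C/c2nc(Nc3ccc(C(C)C)cc3)c3sccc3n2)cc(OC)c1OC`: in a functional assay on L02 cells (Homo sapiens) for inhibition, read by Griess assay, with stated times of 1 h and 24 h (a lower number here means a stronger inhibitor, a higher number a weaker inhibitor), compound 1 gives 370000 nM.
Compound 2 `COc1cc(/C=C/c2nc(NCc3ccccc3Cl)c3sccc3n2)cc(OC)c1OC`: in this assay compound 2 gives only a limit, > 1000000 nM, see (the limit of > 1000000 nM in this assay, at which 1 of the 2 values shown sits).

Compound 2 thus stands at the limit of this assay, with no number of its own. Compound 3 `COc1cc(/C=C/c2nc(NCc3ccncc3)c3sccc3n2)cc(OC)c1OC` differs from compound 2 by pyridin-4-yl in place of 2-chlorophenyl on a saturated chain carbon bound to a nitrogen on an aromatic ring. For the measured compounds named here, the only measured step, an at least 2.7-fold higher number from compound 1 to compound 2 (0.43 log units; beyond the scatter), ends at that limit and concerns a different group, so no measured step bears directly on this change. Compound 3 is therefore expected to remain near the limit, the expected step being a number no higher from compound 2 to compound 3 (the limit leaves the size open). The estimate for compound 3 is 1000000 nM, between 350000 nM and 3000000 nM.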

Compound 3, half-maximal inhibitory concentration: 374000 nM
For compound 3 the middle estimate is 2.7-fold (0.43 log units) above the measured one; the range from low to high includes it.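

In this assay the group on the saturated chain carbon is not confined to the limit: pyridin-4-yl in place of 2-chlorophenyl gives an at least 2.6-fold lower number from compound 2 to compound 3 (0.42 log units; beyond the scatter). Compound 2 carries a limit, so this step is only a bound: the limit of > 1000000 nM in this assay, at which 1 of the 3 values shown sits.

Exchanging 4-isopropylphenyl for (pyridin-4-yl)methyl on the nitrogen gives a 1.0-fold higher number from compound 1 to compound 3 (0.00 log units; within the scatter), so these two groups read alike here.

The change removes the chlorine and brings in the ring nitrogen together, and the two contributions remain unseparated. On these data alone, how a plain phenyl, a pyridin-3-yl or a longer chain before the ring would read remains open.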